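The compounds below may be only part of what the source reports. "The series", "measured", "known", "first", "only" and "open" are said of these compounds alone.

Measured so far:
- compound 1, `CCN(Cc1ccccc1C)C(=O)C1CCN(S(=O)(=O)c2ccc3cn[nH]c3c2)CC1`: 103%
- compound 2, `CC(C)N(Cc1ccccc1C(F)(F)F)C(=O)C1CCN(S(=O)(=O)c2ccc3[nH]ncc3c2)CC1`: 54%
- compound 3, `O=C(C1CCN(S(=O)(=O)c2ccc3[nH]ncc3c2)CC1)N(Cc1ccccc1C(F)(F)F)C1CC1`: "not determined" (no result reported)

Compound 1 `CCN(Cc1ccccc1C)C(=O)C1CCN(S(=O)(=O)c2ccc3cn[nH]c3c2)CC1` in a functional assay on CHO cells for positive allosteric modulation of muscarinic acetylcholine receptor M5 (Homo sapiens), read by calcium flux (on this read-out higher numbers stand for larger maximal responses and lower numbers for smaller maximal responses), gives 103%. Compound 2 `CC(C)N(Cc1ccccc1C(F)(F)F)C(=O)C1CCN(S(=O)(=O)c2ccc3[nH]ncc3c2)CC1` in this assay gives 54%. For the measured compounds named here, no step between these two is worked out here; their two values simply show a higher largest response for compound 1 and a lower one for compound 2, and the two compounds differ in more than one place. Going by the values given here, compound 3 `O=C(C1CCN(S(=O)(=O)c2ccc3[nH]ncc3c2)CC1)N(Cc1ccccc1C(F)(F)F)C1CC1` stands without a number in this assay: no largest response was determined for it, so it gives no anchor for the step to compound 4.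

The change leading to compound 4 `O=C(C1CCN(S(=O)(=O)c2ccc3[nH]ncc3c2)CC1)N(Cc1ccccc1C(F)(F)F)CC1CC1` is:
cyclopropylmethyl in place of cyclopropyl on an amide-type nitrogen
Cyclopropylmethyl in place of cyclopropyl on an amide-type nitrogen is a small change, and no measured pair shows what it does in this assay. With compound 3 unmeasured, no direction can be read from the series. Compound 4 shares its trifluoromethyl-bearing benzyl with compound 2, whose value is 54%, and this is the nearest point of reference. The expected largest response for compound 4 in this assay is therefore estimated at 60%, with a range from 30% to 100%; whether the step from compound 3 exceeds the scatter cannot be said.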

Compound 4, largest response reached (reported as percent of maximum), in percent of the reference or control that the assay uses: 102%
Estimate against measurement, compound 4: 42 percentage points below; the measured number lies above the stated range.
By their numbers in this assay, from the lowest: compound 2; then compounds 4 and 1 (each within the scatter of the next).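

Cyclopropylmethyl in place of isopropyl on an amide-type nitrogen gives a number 48 percentage points higher from compound 2 to compound 4 (beyond the scatter) in this assay, with the trifluoromethyl-bearing benzyl and the rest of the core unchanged. For the compounds shown here, this is the only single-place comparison available, and it shows that the group at this nitrogen can by itself shift the largest response by more than the scatter. The step from cyclopropyl to cyclopropylmethyl cannot be read, as compound 3 has no number, and nothing in the data accounts for the change that can be read.

On these data alone, it remains open whether the gain belongs to the cyclopropylmethyl group in particular or would also appear with a longer chain such as n-butyl, with cyclobutylmethyl, or with a methoxyethyl chain on the same nitrogen. Also open, as far as these compounds go, is whether the step carries over to the 2-methylbenzyl amide of compound 1, which differs from compound 4 in more than one place and so cannot be set on this step.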